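The source may report more compounds than this note shows. Statements on the series, on what has been measured and on what is new or still open speak of the compounds shown alone.

For the measured compounds named here, compound 1 `CCc1ccc(NC(=O)C2CCN(C/C=C/c3ccccc3)CC2)cc1` is the only compound with a plain number in a functional assay on MCF7 cells (Homo sapiens) for inhibition, read by MTT assay, with a stated time of 72 h; a higher number here means a weaker inhibitor, a lower number a stronger inhibitor: in this assay compound 1 gives 20000 nM, so it is a weak inhibitor. Compound 2 `COc1ccccc1NC(=O)C1CCN(C/C=C/c2ccccc2)CC1` reaches only a limit of this assay, and in this assay compound 2 gives > 100000 nM. Going by the values given here, the single measured step, an at least 5.0-fold higher number from compound 1 to compound 2 (0.69 log units; beyond the scatter), shows that swapping the aryl group on the amide-type nitrogen can push the number past the limit (the limit of > 100000 nM in this assay, at which 1 of the 2 values shown sits). Compound 3 `O=C(Nc1cccc(Br)c1)C1CCN(C/C=C/c2ccccc2)CC1` is not yet measured; it differs from compound 1 by 3-bromophenyl in place of 4-ethylphenyl on an amide-type nitrogen. Among the compounds with values here, the one known step points in the weakening direction, but it concerns a different aryl group, so its size is a loose guide only. A modest rise in the number, or none beyond the scatter, is the most that can be read from it. Compound 3 is therefore expected to give about 30000 nM in this assay, within a range of 8000 nM to 100000 nM. The expected step of a 1.5-fold higher number from compound 1 to compound 3 (0.18 log units; within the scatter) reflects that estimate.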

Compound 3, half-maximal inhibitory concentration: 11500 nM
Beside the measured number, compound 3's estimate is 2.6-fold (0.42 log units) above it; measured number inside the range.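

On the amide-type nitrogen, 3-bromophenyl in place of 4-ethylphenyl gives a 1.7-fold lower number from compound 1 to compound 3 (0.24 log units; within the scatter), so this assay does not tell these two aryl groups apart, even though a bromine takes the place of an ethyl group. 3-bromophenyl in place of 2-methoxyphenyl gives an at least 8.6-fold lower number from compound 2 to compound 3 (0.93 log units; beyond the scatter), which shows that the weak result for 2-methoxyphenyl is not shared by every aryl group at this nitrogen, and that this position can tolerate at least some change without the number reaching the top of the range. Compound 2 alone stands at a limit, which is not a true number: the limit of > 100000 nM in this assay, at which 1 of the 3 values shown sits.

The compounds shown do not separate the effect of the methoxy group itself from the effect of where it sits on the phenyl ring. As far as these compounds go, it also remains open whether an amine or a carboxylic acid on this ring, or a longer chain in place of the ethyl group, would move the number beyond the scatter in either direction.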